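The source may hold more compounds than are shown below. What is called first, only, known or untested is meant among the compounds shown, and "the series" means these compounds.

Of the compounds shown here, three have been measured in a functional assay on HT-29 cells (Homo sapiens) for inhibition, read by MTT assay, with a stated time of 72 h; a lower number here means a stronger inhibitor of growth, a higher number a weaker inhibitor of growth. Compound 1 `O=S(=O)(NCCNCc1cccc2ccccc12)c1cc(C(F)(F)F)cc(C(F)(F)F)c1` gives 16000 nM, the highest number of the three. Compound 2 `O=S(=O)(NCCCNCC1COc2ccccc2O1)c1cc(C(F)(F)F)cc(C(F)(F)F)c1` gives 2200 nM, and compound 3 `O=S(=O)(NCCCNCc1ccc(-c2ccccc2)cc1)c1cc(C(F)(F)F)cc(C(F)(F)F)c1` gives 2300 nM; the gaps from compound 1 to each of these lie beyond the usual scatter. Compound 4 `CC(C)(C)c1ccc(CNCCNS(=O)(=O)c2cc(C(F)(F)F)cc(C(F)(F)F)c2)cc1` has not yet been measured. It differs from compound 1 in one place: 4-(tert-butyl)phenyl in place of naphthalen-1-yl on a saturated chain carbon bound to an amine nitrogen. Among the compounds with values here, no two measured compounds differ in just one place, so there is no single measured step to lean on. Compound 3, which carries a different aromatic group, sits well below compound 1 in this assay, which suggests that exchanging the aromatic group can move the number. A modest improvement is therefore expected, a step of a 2.0-fold lower number from compound 1 to compound 4 (0.30 log units; within the scatter). Compound 4 is estimated at 8000 nM, with a range from 2500 nM to 25000 nM.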

Compound 4, concentration for 50% growth inhibition: 14000 nM
Compound 4: middle estimate off by 1.8-fold (0.24 log units), on the low side; measured number inside the range.
By their numbers in this assay, from the lowest: compounds 2 and 3 (each within the scatter of the next); then compounds 4 and 1 (each within the scatter of the next).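

In this assay the exchange of naphthalen-1-yl for 4-(tert-butyl)phenyl on a saturated chain carbon bound to an amine nitrogen gives a 1.1-fold lower number from compound 1 to compound 4 (0.06 log units; within the scatter), so this first one-place comparison shows no real change. At this place, two aromatic rings and one aromatic ring bearing a tert-butyl group, each group holding 10 heavy atoms, are not told apart. Nothing measured here explains this result. Still open, from the compounds shown here alone, is whether a pyridinyl group or a plain phenyl group at this place would move the number.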